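The source may hold more compounds than are shown below. What is called first, only, known or untested is meant among the compounds shown, and "the series" means these compounds.

Compound 1 `COC(=O)C1=CO[C@@H](O[C@@H]2O[C@H](CO)[C@@H](OC(C)=O)[C@H](OC(C)=O)[C@H]2OC(C)=O)[C@@H]2[C@@H](C)[C@@H](OC(C)=O)C[C@H]12` was tested in a functional assay on Caco-2 cells (Homo sapiens) for cytotoxicity, read by MTT assay, with a stated time of 4 h (a lower number here means a stronger inhibitor, a higher number a weaker inhibitor), and is reported as "not active" (no number reported), with no number attached. Among the measured compounds shown here, compound 2 `CCCCCCCCCCCC(=O)OC[C@H]1O[C@@H](O[C@@H]2OC=C(C(=O)OC)[C@H]3C[C@H](OC(C)=O)[C@H](C)[C@@H]23)[C@H](OC(C)=O)[C@@H](OC(C)=O)[C@@H]1OC(C)=O` is the only compound with a numerical result: in this assay compound 2 gives 0.42 ug/mL, so it stands alone as the single measured point of reference, with compound 1 beside it only as an entry without a number. Compound 3 `C=CC(=O)OC[C@H]1O[C@@H](O[C@@H]2OC=C(C(=O)OC)[C@H]3C[C@H](OC(C)=O)[C@H](C)[C@@H]23)[C@H](OC(C)=O)[C@@H](OC(C)=O)[C@@H]1OC(C)=O` is not yet measured; it keeps the shared core of compound 2 and changes one ester: vinyl in place of undecyl on a carbonyl carbon. For the measured compounds named here, no two measured compounds differ in a single place, so there is no measured step to lean on, and the expectation rests on the structural change alone. The step is expected to be a 12-fold higher number from compound 2 to compound 3 (1.08 log units; beyond the scatter), a loss beyond the usual scatter, since the long chain leaves. Compound 3 is therefore estimated at 5 ug/mL, within a range from 1 ug/mL to 30 ug/mL.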

Compound 3, half-maximal inhibitory concentration: "not active" (no number reported)
The entry for compound 3 holds no number, so the estimate cannot be set against anything.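

In this assay, among the compounds shown here, compound 3 is entered as "not active" without a number, so no step from compound 2 to compound 3 can be read. From the compounds shown here alone, how far activity shifts when vinyl replaces undecyl stays open, and no other information here bears on this result.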